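The compounds below may be only part of what the source reports. "The series", "measured", "known", "first", "only" and "open" are said of these compounds alone.

Compound 1 `Cc1c(OCCCCOc2ccc(C(=O)O)c(Cl)c2)ccc(C(=O)CC(C)C)c1O` was examined in an assay on HEK293 cells for positive allosteric modulation of metabotropic glutamate receptor 2 (Rattus norvegicus), read by thallium flux, with a stated time of 2.5 min (a lower number here means a smaller maximal response, a higher number a larger maximal response), where compound 1 gives 80.5%. Its closest companion is compound 2 `Cc1c(OCCCCOc2ccc(C(=O)O)c(Cl)c2)ccc(C(=O)CC2CCCC2)c1O`, which in this assay gives 80.8%. Among the compounds with values here, the one step between the two is a number 0.3 percentage points higher from compound 1 to compound 2 (within the scatter), so compound 1 stands at the lower of the two numbers, with nothing separating it from compound 2 beyond the scatter.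

Compound 3 `Cc1c(OCCCCOc2ccc(C(=O)O)c(Cl)c2)ccc(C(=O)CC(C)C)c1C` differs from compound 1 in one place: methyl in place of hydroxy on an aromatic carbon. Within the data shown here, no measured step speaks to this change. Among the measured compounds shown here, the only step available, from compound 1 to compound 2, touches a different part of the molecule and was within the scatter, so it offers no guide to the hydroxy-to-methyl exchange. In the absence of any bearing data, the step from compound 1 to compound 3 in this assay is expected to be a number 4.5 percentage points lower from compound 1 to compound 3 (within the scatter), though with wide uncertainty. Compound 3 is therefore estimated at 76%, within a range from 45% to 95%.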

Compound 3, largest response reached (reported as percent of maximum), in percent of the reference or control that the assay uses: 33.1%
The estimate for compound 3 lay 42.9 percentage points above the measured number, and the stated range ends above it.
By their numbers in this assay, from the lowest: compound 3; then compounds 1 and 2 (each within the scatter of the next).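

In this assay, methyl in place of hydroxy on this aromatic carbon, ortho to a methyl group and ortho to an isobutylcarbonyl group, gives a number 47.4 percentage points lower from compound 1 to compound 3 (beyond the scatter) and is a large change. Within the data shown here, the only earlier step, cyclopentyl in place of isopropyl on the chain, gave a number 0.3 percentage points higher from compound 1 to compound 2 (within the scatter) and so showed no sensitivity there, whereas this position clearly matters to the maximal response, even for an exchange of one heavy atom for another. Nothing at hand explains the loss.

The compounds shown leave open whether an amino group or a methoxy group on this carbon would keep the response of compound 1, and so whether the hydrogen-bond donor that leaves with hydroxy is what counts. They also leave open whether the same exchange would cost as much with the cyclopentyl chain of compound 2.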